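The source may hold more compounds than are shown below. What is called first, only, known or untested is meant among the compounds shown, and "the series" means these compounds.

Measured compounds:
compound 1 `CCN(CC)C(=O)c1ccc(S(=O)(=O)N2CCC[C@@H](C(=O)N3CCC(F)(F)CC3)C2)cc1` — 240 nM
compound 2 `CCN(CC)S(=O)(=O)c1ccc(S(=O)(=O)N2CCC[C@@H](C(=O)N[C@@H]3CCOC3)C2)cc1` — 2270 nM

In a functional assay on BXPC-3 cells (Homo sapiens) for inhibition, read by MTT assay, with a stated time of 7 days (a lower number here means a stronger inhibitor, a higher number a weaker inhibitor), compound 1 gives the lower of the two numbers; compound 2 gives a number beyond the scatter higher, but the two differ in more than one place, so no single step can be read from them. Compound 3 `CC(C)NS(=O)(=O)c1ccc(S(=O)(=O)N2CCC[C@@H](C(=O)N3CCC(F)(F)CC3)C2)cc1` takes the step from compound 1: isopropylsulfamoyl in place of diethylcarbamoyl on an aromatic carbon. The shared core and the other amide are kept. Among the compounds with values here, the record gives no measured pair for this change alone; a small weakening is expected, of the size a 2.1-fold higher number from compound 1 to compound 3 (0.32 log units; beyond the scatter). In this assay compound 3 is estimated at 500 nM, within 150 nM to 1600 nM.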

Compound 3, half-maximal inhibitory concentration: 470 nM
Beside the measured number, compound 3's estimate is 1.1-fold (0.03 log units) above it, and the stated range covers the measured number.
By their numbers in this assay, from the lowest: compounds 1 and 3 (each within the scatter of the next); then compound 2.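

In this assay, within the data shown here, this is the first step that can be read at a single place: isopropylsulfamoyl in place of diethylcarbamoyl, on an aromatic carbon para to a large group, gives a 2.0-fold higher number from compound 1 to compound 3 (0.29 log units; within the scatter). The position therefore takes a group with a hydrogen-bond donor in place of one without, and the step stays within the scatter. No measurement at hand offers an explanation for this result. Compound 2 differs from compound 3 in more than one place, so that comparison cannot be read. As far as these compounds go, whether a nitrile, a carboxylic acid or an amine would be tolerated on this carbon remains open.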